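The compounds below may be only part of what the source reports. "The series", "measured", "known", "first", "only" and "open" are said of these compounds alone.

In an assay on RPMI-8226 cells for antagonist activity at P2X purinoceptor 7 (Homo sapiens), read by calcium flux (a higher number here means a weaker inhibitor, a lower number a stronger inhibitor), three compounds have been measured:
compound 1, `O=c1[nH]c2ccccc2n1CCCCN1CCN(C(c2ccccc2)c2ccccc2)CC1`, 180 nM;
compound 2, `O=c1[nH]c2ccccc2n1CCCCCN1CCN(C(c2ccccc2)c2ccccc2)CC1`, 560 nM;
compound 3, `Cc1nc2ccccc2n1CCCCN1CCN(C(c2ccccc2)c2ccccc2)CC1`, 850 nM.

Compound 3 stands at the highest of the three numbers, though its gap to compound 2 is within the scatter (a 1.5-fold higher number from compound 2 to compound 3 (0.18 log units; within the scatter)), while the step of a 4.7-fold higher number from compound 1 to compound 3 (0.67 log units; beyond the scatter) lies beyond it. Compound 4, `Cc1cc2ncn(CCCCN3CCN(C(c4ccccc4)c4ccccc4)CC3)c2cc1C`, differs from compound 3 by 5,6-dimethyl-1H-benzimidazol-1-yl in place of 2-methyl-1H-benzimidazol-1-yl on a saturated chain carbon, four bonds along the chain from an amine nitrogen in a ring. Among the measured compounds shown here, no measured pair makes this same exchange; the steps that touch this place, a 3.1-fold higher number from compound 1 to compound 2 (0.49 log units; beyond the scatter) and a 4.7-fold higher number from compound 1 to compound 3 (0.67 log units; beyond the scatter), were both modest, so a modest step or none beyond the scatter is expected here. Compound 4 is therefore estimated at 700 nM in this assay, within 250 nM to 2000 nM, an expected step of a 1.2-fold lower number from compound 3 to compound 4 (0.08 log units; within the scatter).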

Compound 4, half-maximal inhibitory concentration: 770 nM
The estimate for compound 4 lay 1.1-fold (0.04 log units) below the measured number, and the stated range covers the measured number.
By their numbers in this assay, from the lowest: compound 1; then compounds 2, 4 and 3 (each within the scatter of the next).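

In this assay, putting 5,6-dimethyl-1H-benzimidazol-1-yl in place of 2-methyl-1H-benzimidazol-1-yl gives a 1.1-fold lower number from compound 3 to compound 4 (0.04 log units; within the scatter), so this change of methyl groups makes no measurable difference at this position. The number stays close to that of the longer-chain carbonyl compound, at a 1.4-fold higher number from compound 2 to compound 4 (0.14 log units; within the scatter), but remains apart from the best compound, at a 4.3-fold higher number from compound 1 to compound 4 (0.63 log units; beyond the scatter), so the two methyl-bearing groups do not match the carbonyl group on the shorter chain. Nothing measured here explains these results. From the compounds shown here alone, whether an amine or a carboxylic acid in place of these methyl groups, or a shorter chain, would approach compound 1 remains open.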